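From Amino to Piperidin-1-yl: An Expected Gain

The source may report more compounds than this note shows. Statements on the series, on what has been measured and on what is new or still open speak of the compounds shown alone.

Measured compounds:
- compound 1 `O=C(CCc1ccc(C(F)(F)F)cc1)Nc1ccc2nc(N3CCCC3)ccc2c1`, giving 3 nM; 3 nM (2 entries) in an assay on isolated protein for displacement of a labelled ligand from melanin-concentrating hormone receptor 1 (Homo sapiens); on this read-out higher numbers stand for weaker inhibition and lower numbers for stronger inhibition
- compound 2 `Nc1ccc2cc(NC(=O)CCc3ccc(C(F)(F)F)cc3)ccc2n1`, giving 240 nM in this assay

Compound 2 carries the only number shown for it, and that number is the weaker of the two values seen here: in this assay compound 2 gives 240 nM, whereas compound 1 gives 3 nM; 3 nM (2 entries). Compound 3 `O=C(CCc1ccc(C(F)(F)F)cc1)Nc1ccc2nc(N3CCCCC3)ccc2c1` has not yet been measured. It differs from compound 2 in one place: piperidin-1-yl in place of amino on an aromatic carbon. The new group is a six-membered saturated ring attached through its nitrogen, standing where compound 2 has a bare amino group.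

Among the compounds with values here, no step between two measured compounds is given for exactly this change, so the expectation rests on the values themselves. Compound 3 is expected to bind far more strongly than compound 2, because compound 1, which carries a closely related five-membered ring at the same place, gives 3 nM; 3 nM (2 entries). The expected step from compound 2 to compound 3 is a 48-fold lower number from compound 2 to compound 3 (1.68 log units; beyond the scatter), well beyond the usual scatter. Compound 3 is therefore estimated at 5 nM, within a range from 1.5 nM to 25 nM.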

Compound 3, half-maximal inhibitory concentration: 12 nM
Beside the measured number, compound 3's estimate is 2.4-fold (0.38 log units) below it, and the stated range covers the measured number.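

In this assay, replacing the bare amino group with piperidin-1-yl gives a 20-fold lower number from compound 2 to compound 3 (1.30 log units; beyond the scatter), so this position, on an aromatic carbon next to the ring nitrogen, accepts a six-membered saturated ring and binding becomes much stronger. Until now, the gain from a ring here could only be inferred from the separate values of two compounds that differ in one place from neither each other's amino partner nor a shared pair; the new result gives a direct step, and it places compound 3 at 12 nM, much nearer to compound 1 at 3 nM; 3 nM (2 entries) than to compound 2 at 240 nM. The change removes the hydrogen-bond donor of the amino group and adds a ring in one move, and no measurement shown here explains the gain or separates those two parts.

From the compounds shown here alone, it remains open whether the ring itself matters, which a dimethylamino group, with its nitrogen but no ring, could test. A morpholine ring or a larger azepane ring at the same carbon would show how much the ring's make-up and size can vary.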